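Swapping 4-cyanophenyl for 2-bromophenyl in compound 2

A few compounds are considered here, and "the series" means these few. Any claim that something is new, unique, unknown or untested is made for them only; others in the source may bear on it.

- Compound 1 `CN(C)C(=S)N/N=C/c1ccc2cccnc2n1` gives 970 nM
- Compound 2 `N#Cc1ccc(NC(=S)N/N=C/c2ccc3ccccc3n2)cc1` gives 20000 nM

Among the measured compounds shown here, both values come from a functional assay on HeLa cells (Homo sapiens) for antiproliferative activity, read by sulforhodamine B assay, with a stated time of 72 h (on this read-out lower numbers stand for stronger inhibition and higher numbers for weaker inhibition), where only these two compounds have numbers so far. Of the two, compound 2 (20000 nM) stands higher, and the gap down to compound 1 (970 nM) lies beyond the usual scatter of repeated measurements.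

The next compound to be tested is compound 3 `S=C(N/N=C/c1ccc2ccccc2n1)Nc1ccccc1Br`, which changes compound 2 in one place: 2-bromophenyl in place of 4-cyanophenyl on an amide-type nitrogen. In plain terms, 2-bromophenyl takes the place of 4-cyanophenyl on an amide-type nitrogen, and the rest of the molecule stays the same.

For the measured compounds named here, no measured pair shows what this exchange does on its own, so any forecast is loose. Compound 2 (20000 nM) sits at the high end of the numbers seen so far, which leaves more room for a fall than a rise. The expected change is a modest one toward stronger inhibition, estimated as a 2.5-fold lower number from compound 2 to compound 3 (0.40 log units; beyond the scatter). For compound 3 the estimated value is 8000 nM (expected range 1500 nM to 30000 nM).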

Compound 3, half-maximal inhibitory concentration: > 100000 nM
Compound 3 was reported as a limit (the forecaster's own chance of this, stated with the estimate: 10%); middle value at least 12-fold (1.09 log units) from the limit.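

In this assay, placing 2-bromophenyl instead of 4-cyanophenyl on the amide-type nitrogen whose other neighbour is the thiocarbonyl carbon gives an at least 5.0-fold higher number from compound 2 to compound 3 (0.69 log units; beyond the scatter), a move toward weaker inhibition that lies beyond the usual scatter. Among the compounds shown here, this is the first direct evidence that the group on this nitrogen matters, since compound 1 and compound 2 differ in more than one place and could not show this on their own. Compound 3 is reported only as a limit of the assay, not as an exact number, so the step has a minimum size but no known upper end: the limit of > 100000 nM in this assay, at which 1 of the 3 values shown sits.

The two groups differ both in their substituent, bromine or nitrile, and in the number that marks its place in their names, so this single exchange cannot show which of those differences matters. A plain phenyl group with no substituent, or a short chain such as ethyl on the same nitrogen, would show whether this position needs a substituted aromatic ring at all, and whether any group here can reach the level of compound 1 at 970 nM.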